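The compounds below may be only part of what the source reports. "The series", "measured", "known", "first", "only" and "open" are said of these compounds alone.

Of the compounds shown here, two on the shared core have numbers so far in a functional assay on MDA-MB-231 cells (Homo sapiens) for antiproliferative activity, read by MTT assay, with a stated time of 72 h (a lower number here means a stronger inhibitor, a higher number a weaker inhibitor), and both carry their variable group on a carbonyl carbon. Compound 1 `CC1=CC[C@H]2[C@H](CC[C@]2(C)O)C(C)(C)[C@@H]1CC[C@H]1[C@]2(C)CC[C@H](OC(=O)CCC(=O)O)C(C)(C)O[C@H]2CC[C@@]1(C)O` bears 2-carboxyethyl there and gives 27900 nM as its value. Compound 2 `CC1=CC[C@H]2[C@H](CC[C@]2(C)O)C(C)(C)[C@@H]1CC[C@H]1[C@]2(C)CC[C@H](OC(=O)c3ccc(F)cc3)C(C)(C)O[C@H]2CC[C@@]1(C)O` bears 4-fluorophenyl and gives 11300 nM as the lower of the two numbers. Compound 3 `CC1=CC[C@H]2[C@H](CC[C@]2(C)O)C(C)(C)[C@@H]1CC[C@H]1[C@]2(C)CC[C@H](OC(=O)c3ccc(C(F)(F)F)cc3)C(C)(C)O[C@H]2CC[C@@]1(C)O` keeps everything in compound 2 except for trifluoromethyl in place of fluoro on an aromatic carbon, para to a large group. The difference counts as trifluoromethyl in place of fluoro on an aromatic carbon and no more. Among the compounds with values here, only one measured step bears on this change, and it is modest: a 2.5-fold lower number from compound 1 to compound 2 (0.39 log units; beyond the scatter) when the whole group on the carbonyl carbon was exchanged. Within the data shown here, no measured pair varies this aromatic substituent, so the direction is open, and only a smaller step than that one is expected in this assay with none beyond the scatter the likeliest outcome. The expected change is estimated as a 1.2-fold lower number from compound 2 to compound 3 (0.08 log units; within the scatter) with only a slight lean. Compound 3 is estimated at 9500 nM with an expected range from 5000 nM to 19000 nM overall.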

Compound 3, half-maximal inhibitory concentration: 19500 nM
Estimate against measurement, compound 3: 2.1-fold (0.31 log units) below, outside the stated range (above it).
By their numbers in this assay, from the lowest: compounds 2, 3 and 1 (each within the scatter of the next, the first and the last beyond it).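

Trifluoromethyl in place of fluoro on an aromatic carbon, para to a large group, gives the first direct reading of this position: in this assay the step is a 1.7-fold higher number from compound 2 to compound 3 (0.24 log units; within the scatter) and so does not separate the two compounds, although the entering group has 4 heavy atoms against 1 for the group that leaves. The earlier step had suggested that a substituted phenyl on the carbonyl carbon separates from 2-carboxyethyl, but that holds only for the 4-fluorophenyl of compound 2, since the new comparison gives a 1.4-fold lower number from compound 1 to compound 3 (0.16 log units; within the scatter) and compound 3 therefore goes against any such general pattern. Nothing shown explains these numbers, and no measurement of any property of these groups is available to interpret them.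

Still open, going by these compounds, is whether a methoxy group, a nitrile or an amine on the same aromatic carbon would give a number beyond the scatter of compound 2, or whether this position simply tolerates exchange. On these data alone, it is also open how a plain phenyl group or a longer chain ending in a carboxylic acid on the carbonyl carbon would compare with compound 1 and compound 2.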